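Acetyl in place of cyano on the anilide of compound 1

The source may hold more compounds than are shown below. What is called first, only, known or untested is meant among the compounds shown, and "the series" means these compounds.

Measured compounds:
compound 1, `N#Cc1cccc(NC(=O)CSc2nc3cccnc3[nH]2)c1`: 45%
compound 2, `COc1ccc(NC(=O)CSc2nc3ccc(OCC(F)(F)F)nc3[nH]2)cc1OC`: 61%
compound 3, `COc1ccc(CNC(=O)CSc2nc3cccnc3[nH]2)cc1OC`: 0%

In an assay on isolated protein for inhibition of Ectonucleotide pyrophosphatase/phosphodiesterase family member 1 (Homo sapiens), tested at 10 uM (on this read-out higher numbers stand for more inhibition at the one concentration tested (going by the name of the read-out) and lower numbers for less inhibition), compound 1 gives 45%, the second highest of the three numbers. Compound 2 gives 61%, a gap to compound 1 that lies beyond the scatter. Compound 3 gives 0%, far below compound 1 and also beyond the scatter.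

Compound 4, `CC(=O)c1cccc(NC(=O)CSc2nc3cccnc3[nH]2)c1`, differs from compound 1 only in the change (acetyl in place of cyano on an aromatic carbon). Going by the values given here, no step between measured compounds separates these two groups, so no direction can be read from the data. With both groups carrying one acceptor and no donor, a step of no change at the digits printed from compound 1 to compound 4 (within the scatter) is expected, which is none beyond the scatter. Compound 4 is therefore estimated at 45%, in the range 25% to 65%.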

Compound 4, a percentage reported as inhibition, at one concentration (the size of the read-out at that concentration, not a potency): 50%
For compound 4 the middle estimate is 5 percentage points below the measured one; the measured number falls inside the stated range.
By their numbers in this assay, from the lowest: compound 3; then compounds 1 and 4 (each within the scatter of the next); then compound 2.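

Acetyl in place of cyano on the aromatic carbon gives, in this assay, a number 5 percentage points higher from compound 1 to compound 4 (within the scatter), the first step in the series that changes only one place. This position therefore accepts a group of 3 heavy atoms in place of one of 2, and a double bond outside the aromatic ring in place of a triple bond, with no shift beyond the scatter. No evidence bears on this result.

Still open, as far as these compounds go, is how an amine or a carboxylic acid would read on this aromatic carbon. Also open, from the compounds shown here alone, is whether a longer chain than acetyl would stay within the scatter of compound 1.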